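Notes on the series: from compound 2 to compound 3

This account rests on a few compounds, and the source may have more. Where it says the series, first, only, none or still open, it means among the compounds named here.

Measured so far:
compound 1 `Cc1ccccc1-n1nncc1CN1C(=O)C2(C(C#N)=C(N)Oc3c2c2nc4ccccc4nc2c2ccccc32)c2ccccc21` — > 50000 nM
compound 2 `N#CC1=C(N)Oc2c(c3nc4ccccc4nc3c3ccccc23)C12C(=O)N(Cc1cnnn1-c1ccccc1Cl)c1ccccc12` — > 50000 nM

In an ADME assay on HUVEC cells (Homo sapiens) for antiproliferative activity, read by MTT assay, with a stated time of 48 h (a higher number here means a weaker inhibitor, a lower number a stronger inhibitor), compound 1 gives > 50000 nM, which is a limit of the assay and not a number. In this assay compound 2 gives > 50000 nM, likewise a limit. Both values sit at the limit of > 50000 nM in this assay, at which 2 of the 2 values shown sit, so compound 2 stands at the limit, with nothing measured below it. Within the data shown here, the one measured step, a step that the two limits leave unreadable from compound 1 to compound 2, cannot be read, since both its ends are limits.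

Compound 3 `CC(=O)Nc1ccc(-n2nncc2CN2C(=O)C3(C(C#N)=C(N)Oc4c3c3nc5ccccc5nc3c3ccccc43)c3ccccc32)cc1` differs from compound 2 by 4-acetamidophenyl in place of 2-chlorophenyl on an aromatic nitrogen. Among the measured compounds shown here, no measured step bears on this change, and the single step gives no size to lean on. The step of a number no higher from compound 2 to compound 3 (the limit leaves the size open) is therefore expected to be none beyond the scatter, carried from the limit at which compound 2 sits. Compound 3 is expected to give about 50000 nM in this assay, between 15000 nM and 200000 nM, most likely again as a limit.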

Compound 3, half-maximal inhibitory concentration: > 50000 nM
Compound 3: a limit, no number; the forecaster's own chance of this, stated with the estimate: 85%; the middle value lies on the limit itself.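

Compound 3 also gives a limit and not a number in this assay, and the steps from compound 1 and from compound 2 to compound 3 cannot be read. The compounds shown leave open how far any of these aromatic nitrogen substituents changes the activity, with every value at one limit: the limit of > 50000 nM in this assay, at which 3 of the 3 values shown sit.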